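Hydroxy Replaces Nitro: Projecting Cytotoxicity for Compound 4

A few compounds are considered here, and "the series" means these few. Any claim that something is new, unique, unknown or untested is made for them only; others in the source may bear on it.

Measured so far:
Compound 1, `O=C(/C=C/c1ccc(N2CCCC2)cc1)c1ccc([N+](=O)[O-])cc1`, gave 21300 nM.
Compound 2, `COc1cc(O)ccc1/C=C/C(=O)c1ccc(N)cc1`, gave "not determined" (no result reported).
Compound 3, `COc1ccc(/C=C/C(=O)c2cccs2)cc1Br`, gave 21900 nM.

All three were examined in a functional assay on T47D cells (Homo sapiens) for cytotoxicity, read by MTT assay; a lower number here means a stronger inhibitor, a higher number a weaker inhibitor. Compound 1 holds the lowest of the two numbers available, but compound 3 sits so close to it that the two cannot be told apart within the usual scatter of this kind of measurement. Compound 2 adds nothing to the comparison, as no number was obtained for it.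

Compound 4, `O=C(/C=C/c1ccc(N2CCCC2)cc1)c1ccc(O)cc1`, has not yet been measured. It differs from compound 1 in a single place: hydroxy in place of nitro on an aromatic carbon. Within the data shown here, no pair of measured compounds here differs by only one change, so nothing in the numbers shows how large a shift such a replacement brings in this assay , or in which direction. With that gap, the most defensible expectation is a step of modest size, not clearly beyond the scatter, in either direction.

Compound 4 is therefore expected to land near 20000 nM, within a range of 5000 nM to 80000 nM, which would make the estimated step of a 1.1-fold lower number from compound 1 to compound 4 (0.03 log units; within the scatter).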

Compound 4, half-maximal inhibitory concentration: 1370 nM
Compound 4: the middle estimate sits 15-fold (1.16 log units) above what was measured, and the stated range ends above it.
By their numbers in this assay, from the lowest: compound 4; then compounds 1 and 3 (each within the scatter of the next).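

In this assay, hydroxy in place of nitro on this aromatic carbon gives a 16-fold lower number from compound 1 to compound 4 (1.19 log units; beyond the scatter), a step clearly larger than repeat measurements would produce. The earlier compounds shown here included no pair differing in a single place, so they could not show whether this position mattered; this pair shows that a change here alone, with the rest of the core of compound 1 left as it is, can shift the number a long way. It also gives the direction for this one replacement, which lowers the number and so marks a stronger inhibitor on this cytotoxicity read-out.

Nothing shown here explains the shift, and a single step cannot tell whether it comes from the hydroxy entering or the nitro leaving. On these data alone, a methoxy group, an amine or a plain hydrogen on the same aromatic carbon would help separate those two readings, while it remains open whether hydroxy in place of nitro brings a step of similar size on a different core.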